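The compounds below may be only part of what the source reports. "The series", "measured", "known", "first", "only" and "open" are said of these compounds alone.

The study covers three measured compounds and one still unmeasured, all built on a shared core. Within the data shown here, compound 1 `O=C1Nc2ccccc2/C1=N/NC(=S)N1CCCC1` is the first of them. In an ADME assay on RD cells (Homo sapiens) for cytotoxicity (on this read-out lower numbers stand for higher toxicity in this test and higher numbers for lower toxicity in this test), compound 1 gives > 25000 nM, which is a limit of the assay rather than a number. Compound 2 `O=C1Nc2ccccc2/C1=N/NC(=S)Nc1ccc(Br)cc1` carries a 4-bromophenyl group. In this assay compound 2 gives > 25000 nM, again a limit and not a number. Compound 3 `COc1cccc(NC(=O)N/N=C2\C(=O)Nc3ccccc32)c1` completes the measured set. In this assay compound 3 gives > 25000 nM, also a limit. Compound 2 therefore stands exactly where every measured value stands, at the limit of > 25000 nM in this assay, at which 3 of the 3 values shown sit; nothing in the numbers shown separates it from compound 1 or compound 3.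

Compound 4 `O=C1Nc2ccccc2/C1=N/NC(=S)Nc1ccccc1` is the unmeasured member. It differs from compound 2 by hydrogen in place of bromo on an aromatic carbon. Among the measured compounds shown here, no step between measured compounds is available, so the step that the limit leaves unreadable from compound 2 to compound 4 is expected to be none beyond the scatter of this assay. Compound 4 is accordingly estimated at about 30000 nM, between 15000 nM and 60000 nM, most probably reported once more only as a limit.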

Compound 4, half-maximal cytotoxic concentration: > 25000 nM
Compound 4: a limit, no number (the forecaster's own chance of this, stated with the estimate: 85%); the middle value lies beyond the limit too.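

In this assay compound 4 gives > 25000 nM, a limit and not a number. The steps to compound 4 from compound 2 and from compound 1 therefore cannot be read: the limit of > 25000 nM in this assay, at which 4 of the 4 values shown sit. The compounds shown leave open whether hydrogen in place of bromo, or anilino in place of pyrrolidin-1-yl, changes the half-maximal cytotoxic concentration at all.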